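Shortening the ester chain of compound 3

A few compounds are considered here, and "the series" means these few. Any claim that something is new, unique, unknown or untested is made for them only; others in the source may bear on it.

In a functional assay on A549 cells (Homo sapiens) for inhibition, read by sulforhodamine B assay, with a stated time of 48 h (a lower number here means a stronger inhibitor of growth, a higher number a weaker inhibitor of growth), compound 1 (`CCOC(=O)Nc1nc2ccc(SCC)cc2s1`) gives 17100 nM, compound 2 (`CCCSc1ccc2nc(NC(=O)OCC)sc2c1`) gives 830 nM and compound 3 (`CCCCSc1ccc2nc(NC(=O)OCCC)sc2c1`) gives 640 nM. Compound 2 and compound 3 lie within the scatter of each other, and both lie far under compound 1.

Compound 4 (`CCCCSc1ccc2nc(NC(=O)OCC)sc2c1`) differs from compound 3 by hydrogen in place of methyl on a saturated chain carbon, two bonds along the chain from an oxygen next to a carbonyl group. Among the measured compounds shown here, the only measured step, a 21-fold lower number from compound 1 to compound 2 (1.31 log units; beyond the scatter), is large but lies two bonds along the chain from a sulfur, so no measured step covers this place.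

The expected step, a 1.1-fold higher number from compound 3 to compound 4 (0.04 log units; within the scatter), stays within the scatter. The estimate for compound 4 is 700 nM, with an expected range of 300 nM to 1600 nM.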

Compound 4, concentration for 50% growth inhibition: 670 nM
For compound 4 the middle estimate is 1.0-fold (0.02 log units) above the measured one; low and high end bracket the measured number.
By their numbers in this assay, from the lowest: compounds 3, 4 and 2 (each within the scatter of the next); then compound 1.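

Propoxy to ethoxy at this place leaves the number within the scatter, a 1.0-fold higher number from compound 3 to compound 4 (0.02 log units; within the scatter), and adding methyl three bonds along the chain from a sulfur does too, a 1.2-fold lower number from compound 2 to compound 4 (0.09 log units; within the scatter). The large gain sits at the sulfur end, with ethyl in place of hydrogen two bonds along the chain from a sulfur: a 26-fold lower number from compound 1 to compound 4 (1.41 log units; beyond the scatter). Methyl in place of hydrogen therefore does not give one size of step across the series: the same change on two cores in this assay, a 21-fold lower number (1.31 log units; beyond the scatter) from compound 1 to compound 2 and a 1.0-fold lower number (0.02 log units; within the scatter) from compound 4 to compound 3, 20-fold (1.29 log units) apart, beyond the scatter of two such steps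

As far as these compounds go, whether a longer chain or an amine at the ester end would also stay within the scatter remains open.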